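The source may hold more compounds than are shown below. What is called first, only, known or untested is meant among the compounds shown, and "the series" means these compounds.

- compound 1 `CC1=NN(c2ccccc2)C(=O)[C@@]12C(=O)C=CC[C@@H]2c1ccccc1[N+](=O)[O-]` gives 66800 nM
- compound 2 `CC1=NN(c2ccccc2)C(=O)[C@@]12C(=O)C=CC[C@@H]2c1ccc(C)cc1` gives 5220 nM
- compound 3 `CC1=NN(c2ccccc2)C(=O)[C@@]12C(=O)C=CC[C@H]2c1cccc(C)c1` gives 5820 nM

All three numbers come from one test (a functional assay on HCT-116 cells (Homo sapiens) for inhibition, read by MTT assay, with a stated time of 72 h; on this read-out higher numbers stand for weaker inhibition and lower numbers for stronger inhibition). Compound 3 (5820 nM) lies within the usual scatter of compound 2 (5220 nM), and both lie well below compound 1 (66800 nM).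

Going by the values given here, compound 4 `CC1=NN(c2ccccc2)C(=O)[C@@]12C(=O)C=CC[C@@H]2c1cccc(C)c1` has the same atoms and bonds as compound 3 (the two compounds have the same atoms and bonds and differ only in configuration as drawn: 1 of 2 stereo elements differ; a stereocentre at a saturated ring carbon is drawn S in compound 3 and R in compound 4), with a stereocentre at a saturated ring carbon drawn R instead of S. The only measured step, a 13-fold lower number from compound 1 to compound 2 (1.11 log units; beyond the scatter), is a change of group and not of configuration, so it offers no guide to this change. Among the compounds with values here, the expectation therefore stays close to compound 3 (5820 nM) in this assay, with a wide margin because no configuration pair has been measured. The estimated step is a 1.0-fold higher number from compound 3 to compound 4 (0.01 log units; within the scatter), so none beyond the scatter is expected. For compound 4 the estimated value is 6000 nM (expected range 2000 nM to 20000 nM).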

Compound 4, half-maximal inhibitory concentration: 3800 nM
Estimate against measurement, compound 4: 1.6-fold (0.20 log units) above; the measured number falls inside the stated range.
By their numbers in this assay, from the lowest: compounds 4, 2 and 3 (each within the scatter of the next); then compound 1.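

Going by these compounds alone, the first measured change of configuration, a 1.5-fold lower number from compound 3 to compound 4 (0.19 log units; within the scatter) in this assay, shows that drawing this saturated ring carbon R instead of S leaves the number within the scatter for the 3-methylphenyl compounds. Placing 3-methylphenyl in place of 4-methylphenyl gives a 1.4-fold lower number from compound 2 to compound 4 (0.14 log units; within the scatter), also within the scatter, whereas 3-methylphenyl in place of 2-nitrophenyl gives an 18-fold lower number from compound 1 to compound 4 (1.24 log units; beyond the scatter), a large step beyond it. The reading of the first comparison is clean for one reason: the fact that compounds 3 and 4 differ only in the configuration as drawn.

Still open, as far as these compounds go, is how a methoxy group or an amine on this phenyl ring would read. Also open, from the compounds shown here alone, is whether swapping this stereocentre would stay within the scatter with 2-nitrophenyl or 4-methylphenyl in place.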